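Halophenyl swap on the amide nitrogen of compound 1

The source may hold more compounds than are shown below. What is called first, only, known or untested is meant among the compounds shown, and "the series" means these compounds.

Among the compounds with values here, in a functional assay on HCT-116 cells (Homo sapiens) for inhibition, read by MTT assay, with a stated time of 2 days (on this read-out higher numbers stand for weaker inhibition of growth and lower numbers for stronger inhibition of growth), compound 1 (`Nc1ccccc1NC(=O)CCCNCC(=O)Nc1ccc(Br)cc1`) gives 7700 nM, the higher of the two numbers so far. Compound 2 (`Nc1ccccc1NC(=O)c1ccc(NCC(=O)Nc2ccc([N+](=O)[O-])cc2)cc1`) gives 600 nM. Within the data shown here, the gap between these two numbers lies beyond the scatter, but no single-place step links compound 2 to compound 1. Compound 3 (`Nc1ccccc1NC(=O)CCCNCC(=O)Nc1ccccc1Cl`) carries 2-chlorophenyl in place of 4-bromophenyl on an amide-type nitrogen. Among the measured compounds shown here, no measured step covers this change, so no shift beyond the scatter is expected in this assay, and no direction is favoured. The estimated change is a 1.3-fold lower number from compound 1 to compound 3 (0.11 log units; within the scatter). For compound 3 the expected value is 6000 nM, with a range of 2500 nM to 15000 nM.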

Compound 3, concentration for 50% growth inhibition: 21800 nM
The estimate for compound 3 lay 3.6-fold (0.56 log units) below the measured number; measured number outside the range, above it.
By their numbers in this assay, from the lowest: compound 2; then compound 1; then compound 3.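

In this assay, this place on the amide-type nitrogen does respond to the aryl group: 2-chlorophenyl in place of 4-bromophenyl gives a 2.8-fold higher number from compound 1 to compound 3 (0.45 log units; beyond the scatter), a modest weakening of growth inhibition. The two groups are not interchangeable here, although both carry 7 heavy atoms and neither has a hydrogen-bond donor or acceptor. No measurement bears on the reason for this shift.

On these data alone, the step changes the halogen and its ring position together, so their separate contributions remain open. A 4-chlorophenyl or unsubstituted phenyl group at this place would help to separate them.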